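The source may hold more compounds than are shown below. What is called first, only, known or untested is meant among the compounds shown, and "the series" means these compounds.

Measured so far in a physicochemical assay for lipophilicity, read by HPLC, at pH 7.4; a lower number here means a more polar compound, a higher number a more lipophilic compound:
Compound 1 `CNCc1cc(-c2cccnc2C)n(S(=O)(=O)c2cccnc2)c1`: 0.06
Compound 2 `CNCc1cc(-c2cnccc2C)n(S(=O)(=O)c2cccnc2)c1`: -0.51

Compound 2 at -0.51 holds the lower of the two numbers, beyond the scatter. Compound 3 `CNCc1cc(-c2ncccc2C)n(S(=O)(=O)c2cccnc2)c1` has the same atoms joined differently, with 3-methylpyridin-2-yl in place of 4-methylpyridin-3-yl on an aromatic carbon. Going by the values given here, the only measured step that bears on this is a number 0.57 log units lower from compound 1 to compound 2 (beyond the scatter) and it is a modest one, also an exchange of one such group for another. With compound 2 at the low end, a rise of similar size is expected, an estimated a number 0.61 log units higher from compound 2 to compound 3 (beyond the scatter) in this assay for this change. For compound 3 the estimated value is 0.1 with an expected range of -0.4 to 0.6 in this measurement.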

Compound 3, distribution coefficient: 0.53
Compound 3: the middle estimate sits 0.43 log units below what was measured, and the stated range covers the measured number.
By their numbers in this assay, from the lowest: compound 2; then compound 1; then compound 3.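

Going by these compounds alone, exchanging 4-methylpyridin-3-yl for 3-methylpyridin-2-yl on this aromatic carbon gives a number 1.04 log units higher from compound 2 to compound 3 (beyond the scatter), the largest step so far in this assay, while exchanging 2-methylpyridin-3-yl for the same group gives a number 0.47 log units higher from compound 1 to compound 3 (beyond the scatter). Rearranging the same atoms within this group therefore separates all three compounds beyond the scatter, with 3-methylpyridin-2-yl at the high end. Nothing available accounts for this spread. From the compounds shown here alone, it remains open whether the same order would hold with a phenyl ring or a methoxy group in place of the methyl, or with a dimethylamine in place of the (methylamino)methyl group.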